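The source may report more compounds than this note shows. Statements on the series, on what has been measured and on what is new or still open speak of the compounds shown alone.

Compound 1 `O=[N+]([O-])c1cc(CSc2nnc(-c3ccc(Cl)cc3)n2Cc2ccccc2)cc([N+](=O)[O-])c1` and compound 2 `O=[N+]([O-])c1cc(CSc2nnc(C3CCCCC3)n2Cc2ccccc2)cc(C(F)(F)F)c1` share a core that carries a benzyl group and a thioether-linked benzyl bearing a nitro group; they differ in the second substituent on that benzyl and in the group on the carbon of the five-membered ring. In an ADME assay on HepG2 cells (Homo sapiens) for cytotoxicity, with a stated time of 48 h (a higher number here means a weaker inhibitor, a lower number a stronger inhibitor), compound 1 gives > 30000 nM, which is a limit of the assay and not a number. In this assay compound 2 also gives only a limit, > 30000 nM. Compound 2 thus stands at the limit of > 30000 nM in this assay, at which 2 of the 2 values shown sit, and no ordering of the two measured compounds can be drawn from these values. Compound 3 `O=[N+]([O-])c1cc(CSc2nnc(-c3ccc(Cl)cc3)n2Cc2ccccc2)cc(C(F)(F)F)c1` has not yet been measured. The change from compound 2 to compound 3 is 4-chlorophenyl in place of cyclohexyl on an aromatic carbon, with the trifluoromethyl of compound 2 kept. For the measured compounds named here, no step between measured compounds is available to size this change. Compound 1 already carries a 4-chlorophenyl in that place and sits at the limit with > 30000 nM. The step from compound 2 to compound 3 is therefore estimated as a step that the limit leaves unreadable from compound 2 to compound 3, no shift beyond the scatter. Compound 3 is expected to give about 50000 nM, within 20000 nM to 150000 nM, most likely reported again only as a limit.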

Compound 3, half-maximal inhibitory concentration: > 30000 nM
Compound 3 gave a limit, no number; the forecaster's own chance of this, stated with the estimate: 85%; the middle value is on the limit's open side.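

Compound 3 also gives only a limit, so neither its step from compound 2 nor its step from compound 1 can be read in this assay, where all values stand at one limit: the limit of > 30000 nM in this assay, at which 3 of the 3 values shown sit.

The compounds shown leave open whether 4-chlorophenyl or cyclohexyl, or trifluoromethyl or nitro, makes any difference to cytotoxicity at concentrations beyond that limit.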